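Thymol-like Hydroquinone: Isopropyl to tert-Butyl

The source may report more compounds than this note shows. Statements on the series, on what has been measured and on what is new or still open speak of the compounds shown alone.

Compound 1 `CCNC1=C(C)C(=O)C=C(C(C)C)C1=O`: 12600 nM
Compound 2 `Cc1cc(O)c(C(C)C)cc1O`: 3100 nM

Of the compounds shown here, two have been tested in a functional assay on A2780 cells (Homo sapiens) for inhibition, read by sulforhodamine B assay, with a stated time of 72 h; on this read-out lower numbers stand for stronger inhibition and higher numbers for weaker inhibition. Compound 1 gives 12600 nM there, while compound 2 gives 3100 nM; of the two numbers, that of compound 2 is the lower, and its gap to compound 1 lies beyond the usual scatter of the measurement. Compound 3 `Cc1cc(O)c(C(C)(C)C)cc1O` is the next compound for this assay and has not yet been measured. It differs from compound 2 in one place: methyl in place of hydrogen on a saturated chain carbon bound to an aromatic carbon and two saturated chain carbons. For the measured compounds named here, no step between two already measured compounds of this kind is available, so nothing directly shows how such a change affects this assay. A small step is expected from compound 2 to compound 3, a 1.2-fold lower number from compound 2 to compound 3 (0.09 log units; within the scatter), not beyond the scatter in either direction. Compound 3 is therefore estimated at 2500 nM, within a range from 800 nM to 8000 nM.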

Compound 3, half-maximal inhibitory concentration: 6400 nM
The estimate for compound 3 lay 2.6-fold (0.41 log units) below the measured number, within the range that was stated.
By their numbers in this assay, from the lowest: compound 2; then compounds 3 and 1 (each within the scatter of the next).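

In this assay, for the compounds shown here, replacing isopropyl with tert-butyl gives a 2.1-fold higher number from compound 2 to compound 3 (0.31 log units; beyond the scatter), the first direct reading for a change at this position. Adding one methyl on this saturated chain carbon weakens inhibition by a modest step that lies beyond the usual scatter, so the position is sensitive to a change of a single carbon, and the isopropyl compound gives the lower number. Nothing available explains why this step goes in this direction.

As far as these compounds go, whether ethyl, a longer chain such as n-butyl, or a chain ending in an amine or a carboxylic acid would give a lower number at this place stays open. Going by these compounds alone, with only one step in hand, it is also unknown whether the same change would act in the same way on a different core, such as that of compound 1.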